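The compounds below may be only part of what the source reports. "The series", "measured", "known", "first", "only" and "open" are said of these compounds alone.

Measured so far in a functional assay on Flp-In T-REx293 cells for antagonist activity at Free fatty acid receptor 1 (Homo sapiens), read by calcium flux; a higher number here means a weaker inhibitor, a lower number a stronger inhibitor:
- compound 1, `O=S1(=O)c2ccccc2CN1c1cc(F)cc(Oc2cccnc2)c1`: > 100000 nM
- compound 2, `O=S1(=O)c2ccccc2CN1c1cc(F)cc(OCc2ccccc2)c1`: 2450 nM
- compound 3, `Cc1ccc(S(=O)(=O)Nc2ccc(Oc3ccccc3)cc2)cc1`: 10000 nM

The value for compound 1 is a limit of the assay, not a number. Among the two numbers, compound 2 has the lowest; the nearest to it is compound 3, which gives 10000 nM in this assay, a gap beyond the usual scatter.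

Compound 4, `Cc1ccccc1Oc1cc(F)cc(N2Cc3ccccc3S2(=O)=O)c1`, has not yet been measured in this assay. It differs from compound 2 in one place: 2-methylphenyl in place of benzyl on an oxygen on an aromatic ring. For the measured compounds named here, one measured step bears on this change: an at least 40-fold lower number from compound 1 to compound 2 (1.61 log units; beyond the scatter). In that step too, a six-membered aromatic ring gave way to a benzyl on an oxygen on an aromatic ring, and the benzyl gave the far lower number. Compound 4 reverses that kind of change, though with a 2-methylphenyl rather than a pyridin-3-yl, so the size is uncertain. The number for compound 4 is therefore expected to rise, by a step of about a 4.1-fold higher number from compound 2 to compound 4 (0.61 log units; beyond the scatter). Compound 4 is estimated at 10000 nM, with a range from 3000 nM to 40000 nM.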

Compound 4, half-maximal inhibitory concentration: 44700 nM
The estimate for compound 4 lay 4.5-fold (0.65 log units) below the measured number, outside the stated range (above it).
By their numbers in this assay, from the lowest: compound 2; then compound 3; then compound 4. At a limit, above all of these: compound 1.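

In this assay, benzyl and 2-methylphenyl have the same count of heavy atoms and each holds one six-membered aromatic ring of carbon only, yet exchanging them gives an 18-fold higher number from compound 2 to compound 4 (1.26 log units; beyond the scatter). At this place on the oxygen, then, how the carbons are joined matters and not merely how many there are, and the result shows that benzyl's advantage over pyridin-3-yl does not extend to every all-carbon group, even though replacing pyridin-3-yl with 2-methylphenyl gives an at least 2.2-fold lower number from compound 1 to compound 4 (0.34 log units; beyond the scatter). Compound 1 stands at a limit of the assay, so that second step is only a bound: the limit of > 100000 nM in this assay, at which 1 of the 4 values shown sits.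

Going by these compounds, it remains open whether the large step follows from the carbon link between oxygen and ring or from the methyl on the ring. On these data alone, whether a longer chain such as 2-phenylethyl would be tolerated on the oxygen also stays unknown.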